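The source may report more compounds than this note shows. Statements on the series, on what has been measured and on what is new or still open speak of the compounds shown alone.

Of the compounds shown here, three have numbers so far in a functional assay on MCF7 cells (Homo sapiens) for inhibition, read by sulforhodamine B assay, with a stated time of 48 h; on this read-out lower numbers stand for stronger inhibition of growth and higher numbers for weaker inhibition of growth. Compound 1 (`c1cc(NC2=NCCO2)cc(OC2CCCC2)c1`) gives 62100 nM, and compound 3 (`O=C(CCl)NC(=O)Nc1cccc(Oc2ccccc2)c1`) gives 8100 nM. Compound 2 (`O=C(CCl)NC(=O)Nc1ccc(-c2ccccc2)cc1`) gives 3900 nM, the lowest number of the three, and its gap to each of the others lies beyond the usual scatter of repeat measurements.

The next compound to consider is compound 4 (`Cc1ccc(NC(=O)NC(=O)CCl)cc1`). It has methyl in place of phenyl on an aromatic carbon, and otherwise matches compound 2: methyl in place of phenyl on an aromatic carbon. Going by the values given here, no pair of measured compounds shows this change on its own, so the expectation is only a loose one. Replacing phenyl with methyl removes a whole ring, and a clear step toward weaker inhibition of growth is expected rather than none. The expected step is a 2.6-fold higher number from compound 2 to compound 4 (0.41 log units; beyond the scatter). Compound 3, at 8100 nM, gives a rough guide to the level expected. The estimated value for compound 4 is 10000 nM, with an expected range of 3500 nM to 30000 nM.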

Compound 4, concentration for 50% growth inhibition: 7500 nM
Estimate against measurement, compound 4: 1.3-fold (0.12 log units) above, within the range that was stated.
By their numbers in this assay, from the lowest: compounds 2, 4 and 3 (each within the scatter of the next, the first and the last beyond it); then compound 1.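

In this assay, replacing the phenyl with methyl, on an aromatic carbon para to a group of 8 heavy atoms, gives a 1.9-fold higher number from compound 2 to compound 4 (0.28 log units; within the scatter). For this pair, then, a whole six-membered aromatic ring can leave this position and a single methyl can take its place with no change that stands out from the scatter, so the ring is not needed here to keep growth inhibition at this level. Nothing available explains why the two compounds read so alike.

Still open, on these data alone, is how other groups at this position would read, such as a lone hydrogen, a chlorine atom, a methoxy group or an amine. As far as these compounds go, this is also a single pair, and whether the same swap reads alike on a different core remains unknown.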